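The source may hold more compounds than are shown below. What is called first, only, known or untested is meant among the compounds shown, and "the series" means these compounds.

Compound 1, `Cc1ccc(S(=O)(=O)NC2=NCCN2C(=S)SN2CCn3c2nsc3=S)cc1`, and compound 2, `COc1ccc(S(=O)(=O)NC2=NCCN2C(=S)SN2CCn3c2nsc3=S)cc1`, were measured in a functional assay on KYSE-510 cells (Homo sapiens) for antiproliferative activity, read by crystal violet staining, with a stated time of 96 h; a lower number here means a stronger inhibitor of growth, a higher number a weaker inhibitor of growth.

In this assay compound 1 gives only a limit of the assay, >= 20000 nM. In this assay compound 2 likewise gives only a limit, >= 20000 nM. Among the compounds with values here, the single measured step, a step that the two limits leave unreadable from compound 1 to compound 2, is therefore of no readable size, as the limit of >= 20000 nM in this assay, at which 2 of the 2 values shown sit, shows. Compound 2 thus stands at that limit and nowhere more precisely. Compound 3, `O=S(=O)(NC1=NCCN1C(=S)SN1CCn2c1nsc2=S)c1ccc(OC(F)(F)F)cc1`, differs from compound 2 by trifluoromethyl in place of methyl on an oxygen on an aromatic ring. Within the data shown here, no measured step with a readable size bears on this change, and the nearest measured neighbour, compound 2, shows nothing but a limit. The expected outcome is therefore a step of a number no higher from compound 2 to compound 3 (the limit leaves the size open), with the result most likely again reported only as a limit. Compound 3 is expected to give about 20000 nM, with a range from 6000 nM to 20000 nM.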

Compound 3, concentration for 50% growth inhibition: >= 20000 nM
Compound 3: a limit, no number; the forecaster's own chance of this, stated with the estimate: 80%; the middle value lies on the limit itself.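

Compound 3 also gives only a limit of the assay, so no step among compound 1, compound 2 and compound 3 can be read: the limit of >= 20000 nM in this assay, at which 3 of the 3 values shown sit.

What the compounds shown leave open is whether any of these three aromatic groups changes growth inhibition in this assay, since none yields a number.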